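The source may hold more compounds than are shown below. What is called first, only, known or untested is meant among the compounds shown, and "the series" means these compounds.

Within the data shown here, in a functional assay on MKN-7 cells (Homo sapiens) for inhibition, read by sulforhodamine B assay, with a stated time of 48 h (a lower number here means a stronger inhibitor of growth, a higher number a weaker inhibitor of growth), compound 1, `CCCCCCCCCCCC[C@@H](O)[C@H]1CC[C@H]([C@H](O)CCCCCCCCCCN(C)C(=O)c2ccnn2C)O1`, gives 51.3 nM, the lower of the two numbers measured so far, while compound 2, `CCCCCCCCCCCC[C@@H](O)[C@H]1CC[C@H]([C@H](O)CCCCCCCCCCC(=O)Nc2ccnn2C)O1`, gives 20900 nM. Compound 3, `CCCCCCCCCCCC[C@@H](O)[C@H]1CC[C@H]([C@H](O)CCCCCCCCCCOC(=O)c2ccnn2C)O1`, has not yet been measured. It departs from compound 1 by this change: ((1-methyl-1H-pyrazol-5-yl)carbonyl)oxy in place of methyl((1-methyl-1H-pyrazol-5-yl)carbonyl)amino on a saturated chain carbon, ten or more bonds along the chain from an oxygen on a saturated carbon and a saturated ring carbon. The swap lies on a saturated chain carbon.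

Among the measured compounds shown here, only one measured step bears on it, and only in part. That step, a 410-fold higher number from compound 1 to compound 2 (2.61 log units; beyond the scatter), is large, and it puts (1-methyl-1H-pyrazol-5-yl)carbamoyl in place of the group that compound 3 also replaces. Compound 3, however, keeps the (1-methyl-1H-pyrazol-5-yl)carbonyl part of compound 1, which compound 2 does not, so a step of that size is not expected. For the measured compounds named here, no measured compound carries the entering group, so the direction is tentative. A moderate move in this assay towards a higher number is expected, an estimated 2.9-fold higher number from compound 1 to compound 3 (0.47 log units; beyond the scatter). For compound 3 the expected value is 150 nM, with an estimated range from 25 nM to 1500 nM.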

Compound 3, concentration for 50% growth inhibition: 617 nM
Estimate against measurement, compound 3: 4.1-fold (0.61 log units) below; low and high end bracket the measured number.
By their numbers in this assay, from the lowest: compound 1; then compound 3; then compound 2.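

In this assay, the step of a 12-fold higher number from compound 1 to compound 3 (1.08 log units; beyond the scatter) shows that keeping the (1-methyl-1H-pyrazol-5-yl)carbonyl part does not by itself preserve the level of compound 1: exchanging only the methyl-bearing nitrogen for an oxygen at this saturated chain carbon already gives a large loss. The step of a 34-fold lower number from compound 2 to compound 3 (1.53 log units; beyond the scatter) shows that the two groups replacing the methyl((1-methyl-1H-pyrazol-5-yl)carbonyl)amino group are also far from equivalent, so the outcome depends on which linking group joins the chain to the pyrazole, with the order from lowest number being compound 1, compound 3 and compound 2, all separated by steps beyond the scatter. No measurement given here accounts for these differences, so the reason for this order remains unexplained.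

A ((1-methyl-1H-pyrazol-5-yl)carbonyl)amino group, carrying the amide hydrogen in place of the methyl, would help separate the contribution of that methyl from that of the nitrogen itself. From the compounds shown here alone, it also remains open whether the same order would hold with a simple ether link, an amine link or a longer chain at this position.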